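Anilino-to-biaryl switch at the terminal ring, cytotoxicity series

The source may report more compounds than this note shows. Statements on the series, on what has been measured and on what is new or still open speak of the compounds shown alone.

Measured so far:
- compound 1 `C=C[C@@](C)(/C=C/c1ccc(Nc2ccc(F)c(F)c2)cc1)CCC=C(C)C`: > 26000 nM
- compound 2 `C=C[C@@](C)(/C=C/c1ccc(Nc2cc(F)c(F)cc2F)cc1)CCC=C(C)C`: > 26000 nM
- compound 3 `C=C[C@@](C)(/C=C/c1ccc(Nc2c(F)cc(F)cc2F)cc1)CCC=C(C)C`: > 26000 nM

In a functional assay on Raji cells (Homo sapiens) for cytotoxicity, with a stated time of 72 h (on this read-out higher numbers stand for an effect only at larger amounts of compound and lower numbers for an effect already at smaller amounts), compound 1 gives only a limit, > 26000 nM. Compound 2 likewise sits at a limit, > 26000 nM. Compound 3 also returns a limit, > 26000 nM. Because of the limit of > 26000 nM in this assay, at which 3 of the 3 values shown sit, none of the three fluorination patterns on the aryl ring can be ranked; the steps a step that the two limits leave unreadable from compound 1 to compound 2, a step that the two limits leave unreadable from compound 1 to compound 3 and a step that the two limits leave unreadable from compound 2 to compound 3 are all of unreadable size.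

Compound 4 `C=C[C@@](C)(/C=C/c1ccc(-c2ccc(Cl)c(Cl)c2)cc1)CCC=C(C)C` departs from this set: 3,4-dichlorophenyl in place of (3,4-difluorophenyl)amino on an aromatic carbon. Within the data shown here, no measured step touches the linkage between the two aromatic rings or the exchange of fluorine for chlorine, so nothing among the measured steps bears on this change. With compound 1 at a limit, the expectation rests only on the shared core. The estimated step that the limit leaves unreadable from compound 1 to compound 4 is therefore centred near no change, with a wide spread. Compound 4 is expected to give about 30000 nM in this assay, most likely again reported as a limit, within 6000 nM to 150000 nM.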

Compound 4, half-maximal effective concentration: > 26000 nM
Compound 4 ended at the assay's limit; the forecaster's own chance of this, stated with the estimate: 70%; the middle value lies beyond the limit too.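

Compound 4 gives no readable step against compound 1, and no comparison can be drawn, because both values are limits: the limit of > 26000 nM in this assay, at which 4 of the 4 values shown sit.

The compounds shown leave open whether exchanging (3,4-difluorophenyl)amino for 3,4-dichlorophenyl, or changing the fluorination pattern, alters the read-out at all.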